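The source may report more compounds than this note shows. Statements on the series, on what has been measured and on what is new or still open speak of the compounds shown alone.

Of the compounds shown here, three sharing one core have been tested in an assay for activation of interferon regulatory factor 3 (Homo sapiens), read by a luciferase reporter, with a stated time of 20 h; on this read-out higher numbers stand for an effect only at larger amounts of compound and lower numbers for an effect already at smaller amounts. Compound 1, `COc1cc(C(N)=O)cc2nc(NC(=O)c3ccc4ccccc4n3)n(CCCNC(=O)OCc3ccccc3)c12`, carries a quinolin-2-yl group on a carbonyl carbon. In this assay compound 1 gives > 100000 nM, which is a limit of the assay and not a number. Compound 2, `COc1cc(C(N)=O)cc2nc(NC(=O)c3cc4ccccc4n3C)n(CCCNC(=O)OCc3ccccc3)c12`, has 1-methyl-1H-indol-2-yl in that place. In this assay compound 2 gives > 100000 nM, again a limit. Compound 3, `COc1cc(C(N)=O)cc2nc(NC(=O)CCc3ccccc3)n(CCCNC(=O)OCc3ccccc3)c12`, has phenethyl there. In this assay compound 3 gives > 100000 nM, also a limit. Compound 3 thus stands with the other two at the limit of > 100000 nM in this assay, at which 3 of the 3 values shown sit, and the steps a step that the two limits leave unreadable from compound 1 to compound 2, a step that the two limits leave unreadable from compound 1 to compound 3 and a step that the two limits leave unreadable from compound 2 to compound 3 cannot be sized. Compound 4, `COc1cc(C(N)=O)cc2nc(NC(=O)C3CCN(C)CC3)n(CCCNC(=O)OCc3ccccc3)c12`, is still to be measured; the change from compound 3 is 1-methylpiperidin-4-yl in place of phenethyl on a carbonyl carbon. Going by the values given here, no measured step gives a readable size, so the expected step of a number no higher from compound 3 to compound 4 (the limit leaves the size open) has no known size or direction beyond the scatter. Compound 4 is therefore estimated at 100000 nM, between 10000 nM and 300000 nM, most likely reported only as a limit again.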

Compound 4, half-maximal effective concentration: > 100000 nM
Compound 4: a limit, no number; the forecaster's own chance of this, stated with the estimate: 75%; the middle value lies on the limit itself.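

The steps from compound 3, compound 2 and compound 1 to compound 4 cannot be read in this assay, as all four compounds give only a limit of the assay: the limit of > 100000 nM in this assay, at which 4 of the 4 values shown sit.

The compounds shown leave open how the four groups on the carbonyl carbon compare, and whether any group there can give a measured number on the shared core.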